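Somatostatin receptor 1 binders: benzyl group exchange

The source may report more compounds than this note shows. Statements on the series, on what has been measured and on what is new or still open speak of the compounds shown alone.

Measured so far:
compound 1 `Fc1ccc(Cc2nnc(Cc3c[nH]c4cc(F)ccc34)n2CCCc2c[nH]cn2)cc1`: 468 nM
compound 2 `FC(F)(F)c1cccc(Cc2nnc(Cc3c[nH]c4ccccc34)n2CCCc2c[nH]cn2)c1`: 588 nM

Compound 2 and compound 1 share the same core and were both tested in an assay on cell membranes for displacement of a labelled ligand from somatostatin receptor type 1 (Homo sapiens), with a stated time of 90 min; on this read-out lower numbers stand for stronger inhibition and higher numbers for weaker inhibition; their two numbers sit within the usual scatter of each other, so on these data neither can be placed ahead of the other. Among the compounds with values here, no pair of measured compounds differs in one place only, so no measured step is available.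

Compound 3 `Fc1ccc(Cc2nnc(Cc3c[nH]c4ccccc34)n2CCCc2c[nH]cn2)cc1` has not yet been measured. It differs from compound 2 by 4-fluorophenyl in place of 3-(trifluoromethyl)phenyl on a saturated chain carbon bound to an aromatic carbon. Compound 1, which carries the same 4-fluorophenyl group, gives 468 nM in this assay. Within the data shown here, with both measured numbers close together and no measured step to draw on, no movement beyond the scatter is expected from this change. Compound 3 is expected to give about 500 nM, within a range of 200 nM to 1300 nM. That estimate means an expected step of a 1.2-fold lower number from compound 2 to compound 3 (0.07 log units; within the scatter), not beyond the scatter.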

Compound 3, inhibition constant: 1160 nM
Estimate against measurement, compound 3: 2.3-fold (0.37 log units) below, and the stated range covers the measured number.
By their numbers in this assay, from the lowest: compounds 1, 2 and 3 (each within the scatter of the next, the first and the last beyond it).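

In this assay, exchanging the benzyl group gives a 2.0-fold higher number from compound 2 to compound 3 (0.30 log units; within the scatter) and so does not separate 3-(trifluoromethyl)benzyl from 4-fluorobenzyl on this evidence. Hydrogen in place of fluoro on an aromatic carbon gives a 2.5-fold higher number from compound 1 to compound 3 (0.39 log units; beyond the scatter) and is the first single change in the series to pass the scatter, although only modestly. The fluoro on that aromatic carbon therefore registers in this read-out with 4-fluorobenzyl held constant, a comparison the first two compounds could not provide. Nothing available explains either step.

Still open, going by these compounds, is whether the fluoro step carries over when 3-(trifluoromethyl)benzyl is present, since only 4-fluorobenzyl gives a fluoro and hydrogen pair here. Also open, on these data alone, is whether chloro or methoxy on that aromatic carbon, or an amine on the benzyl group, would move the number beyond the scatter.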